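A few compounds are considered here, and "the series" means these few. Any claim that something is new, unique, unknown or untested is made for them only; others in the source may bear on it.

Measured so far:
Compound 1, `O=C(O)c1cccc(-c2nc(Nc3ccccc3F)cs2)c1`: in a physicochemical assay for solubility, using the shake flask method, measured as kinetic solubility, at pH 7.4 (a lower number here means a less soluble compound, a higher number a more soluble compound), compound 1 gives > 100000 nM, which is a limit of the assay and not a number.
Compound 2, `CNC(=O)c1cccc(-c2cnc(Nc3ccc(F)cc3)o2)c1`: in this assay compound 2 gives 3100 nM.

Compound 2 thus holds the only number shown in this assay; the other value is a limit. Compound 3, `Nc1cccc(-c2cnc(Nc3ccc(F)cc3)o2)c1`, has not yet been measured in this assay. The change from compound 2 is amino in place of methylcarbamoyl on an aromatic carbon. Going by the values given here, no step between measured compounds is available to guide the size of this change. For compound 3 the step expected is a 1.0-fold lower number from compound 2 to compound 3 (0.01 log units; within the scatter), within the usual scatter. Compound 3 is estimated at 3000 nM, with a range from 800 nM to 12000 nM.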

Compound 3, solubility: 15200 nM
Beside the measured number, compound 3's estimate is 5.1-fold (0.70 log units) below it; the whole stated range lies below it.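

In this assay, replacing methylcarbamoyl with amino gives a 4.9-fold higher number from compound 2 to compound 3 (0.69 log units; beyond the scatter). Going by these compounds alone, this is the first comparison here in which only one place changes, and it shows that the read-out responds to the group on this aromatic carbon, meta to a large group. Compound 1 differs in more than one place and stands at a limit, not a number: the limit of > 100000 nM in this assay, at which 1 of the 3 values shown sits.

As far as these compounds go, whether a hydroxyl or a dimethylamino group on this carbon would shift the number the same way stays open. So does what lies behind the step, as a single pair cannot tell.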